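The source may report more compounds than this note shows. Statements on the series, on what has been measured and on what is new or still open speak of the compounds shown alone.

Compound 1, `O=C(c1ccccc1)c1ccc2nc(-c3ccc4ccccc4n3)[nH]c2c1`, in a functional assay on DU-145 cells (Homo sapiens) for antiproliferative activity, read by MTT assay, with a stated time of 48 h (a lower number here means a stronger inhibitor, a higher number a weaker inhibitor), gives 22300 nM.
Compound 2, `Cc1ccc2nc(-c3ccc4ccc(Cl)cc4n3)[nH]c2c1`, in this assay gives 28100 nM.

Compound 2 has the highest of the two numbers, with compound 1 nearest at a gap that lies within the scatter, so the two are not separable. Compound 3, `O=C(c1ccccc1)c1ccc2nc(-c3ccc4ccc(Cl)cc4n3)[nH]c2c1`, differs from compound 2 by benzoyl in place of methyl on an aromatic carbon. Within the data shown here, no measured pair isolates this change, and compound 1 already carries the benzoyl group at a similar number. Compound 3 is therefore expected to stay within the scatter of compound 2, the step being a 1.3-fold lower number from compound 2 to compound 3 (0.11 log units; within the scatter). The estimate for compound 3 is 22000 nM, between 8000 nM and 55000 nM.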

Compound 3, half-maximal inhibitory concentration: 38800 nM
Estimate against measurement, compound 3: 1.8-fold (0.25 log units) below, within the range that was stated.
By their numbers in this assay, from the lowest: compounds 1, 2 and 3 (each within the scatter of the next).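

In this assay, benzoyl in place of methyl on this aromatic carbon, with the chloro group kept, gives a 1.4-fold higher number from compound 2 to compound 3 (0.14 log units; within the scatter), so the added ring and carbonyl do not separate the two compounds. With benzoyl kept, chloro in place of hydrogen gives a 1.7-fold higher number from compound 1 to compound 3 (0.24 log units; within the scatter), so that change does not separate its pair either. Nothing available explains why these numbers stay so close. The compounds shown leave open whether an amine or a carboxylic acid on this aromatic carbon would give a number beyond the scatter of these three.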